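Fluorophenyl Swap on a Piperazine T-type Channel Series

The source may report more compounds than this note shows. Statements on the series, on what has been measured and on what is new or still open speak of the compounds shown alone.

Measured compounds:
compound 1, `CCCc1nc(-c2ccccc2)c(CNCCCN2CCN(c3cccc(F)c3)CC2)o1`: 68.9%
compound 2, `CCCc1nc(-c2ccccc2)c(CNCCCN2CCN(c3ccc(C(F)(F)F)cc3)CC2)o1`: 51.6%
compound 3, `CCCc1nc(-c2ccccc2)c(CNCCN2CCN(c3ccc(C(F)(F)F)cc3)CC2)o1`: 58.7%

All three were tested in an assay on HEK293 cells for inhibition of Voltage-dependent T-type calcium channel subunit alpha-1G (Homo sapiens), read by fluorescence, tested at 10 uM; on this read-out higher numbers stand for more inhibition at the one concentration tested (going by the name of the read-out) and lower numbers for less inhibition. Compound 1 gives 68.9% and compound 2 gives 51.6%; the two share a core and differ by one change, (3-fluorophenyl in place of 4-(trifluoromethyl)phenyl on an amine nitrogen in a ring), which made the step of a number 17.3 percentage points higher from compound 2 to compound 1 (beyond the scatter). Compound 3 gives 58.7%; its core and that of compound 2 are not broken down here into a counted difference, and their two values lie within the scatter of each other, so no order between them is claimed. Compound 3 stands beyond the scatter from compound 1 only.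

The unmeasured compound 4, `CCCc1nc(-c2ccccc2)c(CNCCN2CCN(c3cccc(F)c3)CC2)o1`, is obtained from compound 3 by 3-fluorophenyl in place of 4-(trifluoromethyl)phenyl on an amine nitrogen in a ring. The place line for this change reads the same as for the change from compound 2 to compound 1, so it is taken as the same change made on a second core. Among the compounds shown it occurs twice in all.

Going by the values given here, compound 4 is expected to show a step of a number 12.3 percentage points higher from compound 3 to compound 4 (beyond the scatter) in this assay, because the one earlier instance of this change gave a number 17.3 percentage points higher from compound 2 to compound 1 (beyond the scatter), though with only a single precedent the size is uncertain. Compound 4 is therefore estimated at 71%, with a likely range from 58% to 84%.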

Compound 4, a percentage reported as inhibition, at one concentration (the size of the read-out at that concentration, not a potency): 62.3%
For compound 4 the middle estimate is 8.7 percentage points above the measured one; the range from low to high includes it.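

On the second core, the same swap of 4-(trifluoromethyl)phenyl for 3-fluorophenyl gave in this assay a number 3.6 percentage points higher from compound 3 to compound 4 (within the scatter), so on this core alone the change has no effect that can be told from repeat variation. Set beside the first instance, the two steps do not differ by more than two such steps can be expected to scatter: the same change on two cores in this assay, a number 17.3 percentage points higher (beyond the scatter) from compound 2 to compound 1 and a number 3.6 percentage points higher (within the scatter) from compound 3 to compound 4, 13.7 percentage points apart, within the scatter of two such steps This means the two results can be read as one effect of similar size on both cores, but they do not prove it, since the step on one core lies beyond the scatter and the step on the other within it, and two instances fix neither a common size for the change nor a dependence on the core.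

The compounds shown leave open whether the same pattern would hold for other groups on the amine nitrogen in a ring, such as 4-fluorophenyl, 3-chlorophenyl or unsubstituted phenyl, or with a longer chain in the core. They also leave open how these percentages at one concentration in this assay relate to potency, which a single-concentration read-out does not give.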